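The source may hold more compounds than are shown below. What is called first, only, known or untested is meant among the compounds shown, and "the series" means these compounds.

For the measured compounds named here, compound 2 `O=C(Nc1c(C(O)(C(F)(F)F)C(F)(F)F)ccc2ccccc12)c1ccc(Cl)c(Cl)c1` stands highest of the two numbers so far: in an assay on LtK cells with ATP-sensitive inward rectifier potassium channel 11 (Homo sapiens) as the target (on this read-out lower numbers stand for an effect already at smaller amounts and higher numbers for an effect only at larger amounts of compound), compound 2 gives 194 nM, whereas compound 1 `O=C(Nc1c(C(O)(C(F)(F)F)C(F)(F)F)ccc2ccccc12)c1ccc(Br)cc1` gives 47 nM. Going by the values given here, the only measured step, a 4.1-fold higher number from compound 1 to compound 2 (0.62 log units; beyond the scatter), concerns an exchange of the whole aryl group on the carbonyl carbon. Compound 3 `O=C(Nc1c(C(O)(C(F)(F)F)C(F)(F)F)ccc2ccccc12)c1cc(Cl)cc(Cl)c1` keeps both chlorines and moves one of them: 3,5-dichlorophenyl in place of 3,4-dichlorophenyl on a carbonyl carbon. Among the compounds with values here, no measured step covers such a shift of substituents within the dichlorophenyl, so no direction can be read from the series; a step in this assay within the usual scatter is expected, a 1.2-fold lower number from compound 2 to compound 3 (0.08 log units; within the scatter). Compound 3 is therefore expected at 160 nM, with a range from 45 nM to 550 nM.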

Compound 3, half-maximal effective concentration: 306 nM
Compound 3: the middle estimate sits 1.9-fold (0.28 log units) below what was measured; the measured number falls inside the stated range.
By their numbers in this assay, from the lowest: compound 1; then compounds 2 and 3 (each within the scatter of the next).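

Within the dichlorophenyl pair, moving one chlorine shows a 1.6-fold higher number from compound 2 to compound 3 (0.20 log units; within the scatter) in this assay and so does not separate the 3,4-dichlorophenyl from the 3,5-dichlorophenyl at this position. Set against the 4-bromophenyl, the 3,5-dichlorophenyl shows a 6.5-fold higher number from compound 1 to compound 3 (0.81 log units; beyond the scatter) and so, like the 3,4-dichlorophenyl, stands clear of the bromo compound. No measurement accompanies these numbers that could account for them. Open, from the compounds shown here alone, is how 4-chlorophenyl would read here, which would separate the bromine from the pair of chlorines. Going by these compounds, a phenyl carrying an amine or a carboxylic acid on this carbonyl carbon also remains open.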